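A few compounds are considered here, and "the series" means these few. Any claim that something is new, unique, unknown or untested is made for them only; others in the source may bear on it.

Compound 1 `Nc1ccccc1NC(=O)c1ccc(CSc2nccc(C(F)(F)F)n2)cc1` gives 970 nM in a functional assay on A549 cells (Homo sapiens) for antiproliferative activity, read by CCK-8 assay, with a stated time of 72 h; on this read-out lower numbers stand for stronger inhibition and higher numbers for weaker inhibition. Compound 2 `Cc1ccc(SCc2ccc(C(=O)Nc3ccccc3N)cc2)cc1`, built on the same shared core, gives 3270 nM in this assay. On these data alone, compound 3 `Nc1ccccc1NC(=O)c1ccc(CSc2cccc(F)c2)cc1` carries a different group on the sulfur, yet in this assay compound 3 is recorded only as "not determined" (no result reported), so compound 3 stands nowhere on these numbers and its potency remains unknown. Compound 4 `CCc1ccc(SCc2ccc(C(=O)Nc3ccccc3N)cc2)cc1` differs from compound 3 in a single place (4-ethylphenyl in place of 3-fluorophenyl on a sulfur). Since compound 3 is unmeasured, neither the size nor the direction of this step can be read off, and no step beyond the usual scatter can be asserted. Among the measured compounds, compound 4 most closely resembles compound 2, which gives 3270 nM. On that basis, compound 4 is expected to give about 3500 nM in this assay, with a range from 1200 nM to 10000 nM.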

Compound 4, half-maximal inhibitory concentration: 3040 nM
Compound 4: the middle estimate sits 1.2-fold (0.06 log units) above what was measured; low and high end bracket the measured number.
By their numbers in this assay, from the lowest: compound 1; then compounds 4 and 2 (each within the scatter of the next).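

In this assay, placing a methyl in place of hydrogen on the saturated chain carbon bound to an aromatic carbon gives a 1.1-fold lower number from compound 2 to compound 4 (0.03 log units; within the scatter), so this small addition to the group on the sulfur leaves the number unchanged within the scatter. The step from compound 3 to compound 4 cannot be read, as compound 3 has no value. Nothing measured here offers an explanation for this result. Still open, on these data alone, is whether a longer chain, such as butyl, or an amine on that aromatic ring would move the number, and where the 3-fluorophenyl group stands.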